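Freeing One Oxygen on Compound 3

A few compounds are considered here, and "the series" means these few. Any claim that something is new, unique, unknown or untested is made for them only; others in the source may bear on it.

In a functional assay on MCF7 cells (Homo sapiens) for antiproliferative activity, read by MTT assay (a lower number here means a stronger inhibitor, a higher number a weaker inhibitor), compound 1 `CC/C=C\C/C=C\C/C=C\CCCCCCCC1(O)CC(=O)c2c(O)cc(OCOC)cc2O1` gives 17500 nM. Compound 2 `CCCC/C=C\CCCCCCCCCc1cc(=O)c2c(O)c(C)c(OCOC)cc2o1` gives only a limit, > 67200 nM. Compound 3 `CCCCCCCCCCCCCCCc1cc(=O)c2c(O)c(C)c(OCOC)cc2o1` also gives only a limit, > 67200 nM, so no number fixes its place. Compound 4 `CCCCCCCCCCCCCCCc1cc(=O)c2c(O)c(C)c(O)cc2o1` differs from compound 3 by hydrogen in place of methoxymethyl on an oxygen on an aromatic ring, which turns methoxymethoxy to hydroxy. Going by the values given here, the one measured step, a step that the two limits leave unreadable from compound 2 to compound 3, lies in the chain and not at this oxygen, so no measured step gives a size for this change. Among the compounds with values here, the only readable value, compound 1 at 17500 nM, offers just a weak guide. A modest, uncertain move toward stronger inhibition is expected, an at least 1.9-fold lower number from compound 3 to compound 4 (0.28 log units; that floor lies within the scatter). For compound 4 the estimated value is 35000 nM, with an expected range of 12000 nM to 90000 nM.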

Compound 4, half-maximal inhibitory concentration: 43200 nM
Compound 4: the middle estimate sits 1.2-fold (0.09 log units) below what was measured, and the stated range covers the measured number.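

Freeing this oxygen on the aromatic ring, with hydroxy in place of methoxymethoxy, brings the saturated chain series onto a readable scale in this assay, and the change can now be given a size: an at least 1.5-fold lower number from compound 3 to compound 4 (0.19 log units; that floor lies within the scatter). That size is only a floor, so the true step could be larger, because compound 3 carries a limit and not a number: the limit of > 67200 nM in this assay, at which 2 of the 4 values shown sit.

From the compounds shown here alone, how large the step really is remains open. So does whether a methyl ether or an amine at this place would give a lower number than the hydroxy of compound 4.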